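A few compounds are considered here, and "the series" means these few. Any claim that something is new, unique, unknown or untested is made for them only; others in the source may bear on it.

Of the compounds shown here, three that share one core have been tested so far. Compound 1 (`O=C(CCCCC1CCSS1)Nc1cccc(C(F)(F)F)c1`) gives 4.39% in a functional assay on NCI-H460 cells (Homo sapiens) for inhibition, read by MTT assay, with a stated time of 24 h, tested at 1 ug/mL (a lower number here means less inhibition of growth, a higher number more inhibition of growth at the concentration tested), and compound 2 (`O=C(CCCCC1CCSS1)Nc1ccc(Br)cn1`) gives 13.1% under the same conditions, while compound 3 (`O=C(CCCCC1CCSS1)Nc1cccc2ccccc12`) gives 4.15% there too. Compound 3 cannot be ranked against the other two, since its gaps to compound 1 and to compound 2 both lie within the usual scatter.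

The next structure, compound 4 (`O=C(CCCCC(S)CCS)Nc1cccc2ccccc12`), keeps everything in compound 3 except one part: a group of 5 heavy atoms (3 carbon, 2 sulfur; no ring) in place of a group of 5 heavy atoms (3 carbon, 2 sulfur; one five-membered non-aromatic ring with 2 hetero atoms), on a saturated chain carbon, four bonds along the chain from a carbonyl carbon is the whole change. A 1,3-disulfanylpropyl group with no ring replaces the five-membered non-aromatic ring, on a saturated chain carbon, four bonds along the chain from a carbonyl carbon.

Going by the values given here, no measured pair shows what this change does, so any forecast here is loose. Among the compounds with values here, the only guide is that compound 2 at 13.1% and compound 3 at 4.15% remain within scatter of each other although they carry different groups on the amide. The expected move is a number 5.9 percentage points higher from compound 3 to compound 4 (within the scatter) as a small upward step that stays within the scatter, though a larger rise cannot be ruled out. For compound 4 the estimated value is 10% with an expected range from 1% to 28% in this assay when the measurement arrives.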

Compound 4, percent growth inhibition at one concentration: "not active" (no number reported)
For compound 4 the study gives words and no number; there is nothing to compare the estimate with.
By their numbers in this assay, from the lowest: compounds 3, 1 and 2 (each within the scatter of the next).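

Going by these compounds alone, compound 4 is reported only in words as not active in this assay, so no step from compound 3 to compound 4 can be read. The compounds shown leave open how the 1,3-disulfanylpropyl group would compare with the ring on the amides of compound 1 and compound 2. Nothing here bears on the reason for this result.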